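This account rests on a few compounds, and the source may have more. Where it says the series, first, only, none or still open, it means among the compounds named here.

Compound 3 `Cc1noc(C[S+]([O-])C(c2ccccc2)c2ccccc2)n1` gives 56700 nM in an assay on HEK293 cells for inhibition of sodium-dependent dopamine transporter (Homo sapiens), read by scintillation counting, with stated times of 5 min and 1 min; a lower number here means a stronger inhibitor, a higher number a weaker inhibitor. Among the three measured compounds it has the second highest number: compound 2 `CC(C)c1nnsc1C[S+]([O-])C(c1ccccc1)c1ccccc1` gives 69100 nM and sits within the scatter of it, the step being a 1.2-fold lower number from compound 2 to compound 3 (0.09 log units; within the scatter), while compound 1 `[O-][S+](Cc1cc(Br)cs1)C(c1ccccc1)c1ccccc1` gives 13700 nM and is the furthest away, with a 4.1-fold higher number from compound 1 to compound 3 (0.62 log units; beyond the scatter). Compound 4 `Cc1cnc(C[S+]([O-])C(c2ccccc2)c2ccccc2)nc1` has not been measured. It differs from compound 3 in one place: 5-methylpyrimidin-2-yl in place of 3-methyl-1,2,4-oxadiazol-5-yl on a saturated chain carbon bound to a sulfur. Every measured step here exchanges the same group on the saturated chain carbon bound to a sulfur. The step of a 5.0-fold higher number from compound 1 to compound 2 (0.70 log units; beyond the scatter) and the step of a 4.1-fold higher number from compound 1 to compound 3 (0.62 log units; beyond the scatter) show that replacing the 4-bromothiophen-2-yl with either five-membered ring raises the number, whereas between the two five-membered rings a 1.2-fold lower number from compound 2 to compound 3 (0.09 log units; within the scatter) stays within the scatter. Among the compounds with values here, no measured compound carries a six-membered ring, so the data give no direct guide for the 5-methylpyrimidin-2-yl. The expected step is a 1.3-fold lower number from compound 3 to compound 4 (0.10 log units; within the scatter), which need not exceed the scatter. The estimate for compound 4 is 45000 nM, ranging from 15000 nM to 130000 nM.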

Compound 4, half-maximal inhibitory concentration: 156000 nM
For compound 4 the middle estimate is 3.5-fold (0.54 log units) below the measured one; measured number above the stated range.
By their numbers in this assay, from the lowest: compound 1; then compounds 3 and 2 (each within the scatter of the next); then compound 4.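

In this assay, this position on the saturated chain carbon bound to a sulfur proves more sensitive than the two five-membered rings of compound 2 and compound 3 suggested: the 5-methylpyrimidin-2-yl gives a 2.8-fold higher number from compound 3 to compound 4 (0.44 log units; beyond the scatter) and a 2.3-fold higher number from compound 2 to compound 4 (0.35 log units; beyond the scatter). Set against the 4-bromothiophen-2-yl, the same group gives an 11-fold higher number from compound 1 to compound 4 (1.06 log units; beyond the scatter), the largest step in the set, and this makes compound 4 the weakest of the four inhibitors. Nothing measured here accounts for this result.

Within the data shown here, with only one six-membered ring in the set, the compounds leave open whether the higher number goes with the ring size or with this particular ring and its methyl group. On these data alone, a plain phenyl or a pyridin-2-yl on the same carbon would bear on that, and how an amine or a carboxylic acid would fare at this position also remains open.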